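The compounds below may be only part of what the source reports. "The series", "measured", "known", "first", "only" and "open" are said of these compounds alone.

In a functional assay on COLO 205 cells (Homo sapiens) for cytotoxicity, read by sulforhodamine B assay, with a stated time of 48 h (on this read-out lower numbers stand for stronger inhibition and higher numbers for weaker inhibition), compound 1 `COc1cc(/C=C/C(=O)/C=C/c2cccc3ccccc23)ccc1OCc1cn(CCOc2cc(=O)oc3ccccc23)nn1` gives 9950 nM, compound 2 `COc1cc(/C=C/C(=O)/C=C/c2cccc3ccccc23)ccc1OCc1cn(CCCOc2cc(=O)oc3ccccc23)nn1` gives 12700 nM and compound 3 `COc1cc(/C=C/C(=O)/C=C/c2cc(OC)c(OC)c(OC)c2)ccc1OCc1cn(CCOc2cc(=O)oc3ccccc23)nn1` gives 4680 nM, the lowest of the three numbers. Compound 4 `COc1ccccc1/C=C/C(=O)/C=C/c1ccc(OCc2cn(CCOc3cc(=O)oc4ccccc34)nn2)c(OC)c1` differs from compound 3 in one place: 2-methoxyphenyl in place of 3,4,5-trimethoxyphenyl on a double-bonded chain carbon bound to a double-bonded chain carbon. It has 2-methoxyphenyl in place of 3,4,5-trimethoxyphenyl on a double-bonded chain carbon bound to a double-bonded chain carbon. Among the measured compounds shown here, only one measured step bears on this place: a 2.1-fold lower number from compound 1 to compound 3 (0.33 log units; beyond the scatter), with 3,4,5-trimethoxyphenyl in place of naphthalen-1-yl. For the measured compounds named here, that step was modest, and no measured compound carries 2-methoxyphenyl, so only a modest rise is expected in this assay. The expected change is a 1.6-fold higher number from compound 3 to compound 4 (0.20 log units; within the scatter). For compound 4 the estimated value is 7500 nM, with an expected range of 3500 nM to 16000 nM.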

Compound 4, half-maximal inhibitory concentration: 11500 nM
The estimate for compound 4 lay 1.5-fold (0.19 log units) below the measured number, and the stated range covers the measured number.
By their numbers in this assay, from the lowest: compound 3; then compounds 1, 4 and 2 (each within the scatter of the next).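

In this assay, a second change at the place on a double-bonded chain carbon bound to a double-bonded chain carbon gives a 2.5-fold higher number from compound 3 to compound 4 (0.39 log units; beyond the scatter), with 2-methoxyphenyl in place of 3,4,5-trimethoxyphenyl. Set against naphthalen-1-yl, 2-methoxyphenyl gives a 1.2-fold higher number from compound 1 to compound 4 (0.06 log units; within the scatter), so of these three groups only 3,4,5-trimethoxyphenyl stands apart. Nothing available accounts for this difference. Compound 3 gives 4680 nM, and the compounds shown leave open whether a pyridine ring or a dimethylaminophenyl group at this place would give a lower number. They also leave open how an unsubstituted phenyl would compare.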